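Removing the fluoro from a shared core in colon cancer cells

This account rests on a few compounds, and the source may have more. Where it says the series, first, only, none or still open, it means among the compounds named here.

Measured so far:
Compound 1 `CCC(CCO)n1cnc2c(Cl)nc(F)nc21` gives 18900 nM.
Compound 2 `CCC(CCO)n1cnc2c(Cl)ncnc21` gives > 50000 nM, which is a limit of the assay and not a number.
Compound 3 `CCCCCC(CCO)n1cnc2c(Cl)nc(F)nc21` gives 8660 nM.

These values come from a functional assay on HCT-116 cells (Homo sapiens) for antiproliferative activity, read by MTT assay, with a stated time of 48 h; on this read-out higher numbers stand for weaker inhibition and lower numbers for stronger inhibition. Compound 1 and compound 2 differ by one change, (hydrogen in place of fluoro on an aromatic carbon), and this gave an at least 2.6-fold higher number from compound 1 to compound 2 (0.42 log units; beyond the scatter); compound 2 sits at the limit of > 50000 nM in this assay, at which 1 of the 3 values shown sits. Compound 3 differs from compound 1 by propyl in place of hydrogen on a saturated chain carbon, three bonds along the chain from an aromatic nitrogen, which gave a 2.2-fold lower number from compound 1 to compound 3 (0.34 log units; beyond the scatter).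

Compound 4 `CCCCCC(CCO)n1cnc2c(Cl)ncnc21` has not yet been measured. It differs from compound 3 by hydrogen in place of fluoro on an aromatic carbon, the same change as from compound 1 to compound 2, at the same place on the same kind of ring. On the evidence of compound 1 and compound 2, where this change gave an at least 2.6-fold higher number from compound 1 to compound 2 (0.42 log units; beyond the scatter), compound 4 is expected to show a 3.5-fold higher number from compound 3 to compound 4 (0.54 log units; beyond the scatter). Compound 4 is therefore estimated at 30000 nM in this assay, likely between 15000 nM and 60000 nM, with a real chance that only a limit is reported.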

Compound 4, half-maximal inhibitory concentration: > 50000 nM
Compound 4: a limit, no number; the forecaster's own chance of this, stated with the estimate: 35%; middle value at least 1.6-fold (0.22 log units) from the limit.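

In this assay compound 4 gives > 50000 nM, which is a limit of the assay and not a number. Putting hydrogen in place of the fluoro gave an at least 5.7-fold higher number from compound 3 to compound 4 (0.76 log units; beyond the scatter), so on both cores the change points the same way, toward weaker inhibition, but this does not show that its size is the same or that it differs: the same change on two cores in this assay, an at least 2.6-fold higher number (0.42 log units; beyond the scatter) from compound 1 to compound 2 and an at least 5.7-fold higher number (0.76 log units; beyond the scatter) from compound 3 to compound 4; the limit leaves it open whether they differ. Both compounds without the fluoro stop at one shared limit, so adding the propyl on the core without fluoro gives a step that cannot be read, and nothing can be said about what that chain does there: the limit of > 50000 nM in this assay, at which 2 of the 4 values shown sit.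

The compounds shown leave open how much weaker compound 2 and compound 4 really are, and so whether the loss on removing the fluoro is larger on one core than on the other. They also leave open what an amine or a methoxy group would do on the aromatic carbon between the two ring nitrogen atoms, where only fluoro and hydrogen appear here.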